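Working notes: replacing the 4-acetamidophenyl group

The compounds below may be only part of what the source reports. "The series", "measured", "known", "first", "only" and "open" are said of these compounds alone.

Compound 1 `COc1ccc(-c2c(C)nc3c(N4CC[C@@H](NC(=O)Oc5cccc(C)c5)C4)cc(C)nn23)cc1OC`: > 95%
Compound 2 `COc1ccc(-c2c(C)nc3c(N4CC[C@@H](NS(=O)(=O)c5ccc(C)cc5)C4)cc(C)nn23)cc1OC`: > 95%
Compound 3 `COc1ccc(-c2c(C)nc3c(N4CC[C@@H](NS(=O)(=O)c5ccc(NC(C)=O)cc5)C4)cc(C)nn23)cc1OC`: > 95%

All three results come from an ADME assay on microsomes from liver (Mus musculus) for metabolic stability, read by LC-MS, with NADPH named in the record, with a stated time of 60 min, tested at 1 uM, in the absence of a further agent (a lower number here means that less of the compound is left, a higher number that more of the compound is left), and each is a limit, not a number. Compound 3 therefore has no exact position in the series.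

Compound 4 `COc1ccc(-c2c(C)nc3c(N4CC[C@@H](NS(N)(=O)=O)C4)cc(C)nn23)cc1OC` carries amino in place of 4-acetamidophenyl on a sulfonyl sulfur.

Among the compounds with values here, two measured steps bear on this change. The first, a step that the two limits leave unreadable from compound 2 to compound 3, alters a group on the same aromatic ring that now leaves. The second, a step that the two limits leave unreadable from compound 1 to compound 2, exchanges the group on an amine nitrogen. Neither has a readable size, so neither sets a scale, and neither removes the aromatic ring. Within the data shown here, the only remaining guide is the limit of > 95% in this assay, at which 3 of the 3 values shown sit, which is weak support for an expectation of no step beyond the scatter in this assay.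

The estimated change is a number at least 1 percentage points lower from compound 3 to compound 4 (that floor lies within the scatter).

For compound 4 the expected value is 94%, with an estimated range of 78% to 100%.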

Compound 4, percent of the compound remaining: > 95%
Compound 4: no number, only a limit; the forecaster's own chance of this, stated with the estimate: 55%; middle value at least 1 percentage points from the limit.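

In this assay, within the data shown here, compound 4 gives > 95%, a limit and not a number, so no step to it from compound 1, compound 2 or compound 3 can be read. The compounds shown leave open whether any of these changes alters the percent of compound remaining.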